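This account rests on a few compounds, and the source may have more. Where it says the series, first, only, none or still open, it means among the compounds named here.

Measured so far in a functional assay on the whole organism (Cricetulus griseus) with Cricetinae gen. sp. as the target; a higher number here means that more compound is needed for the effect, a lower number that less compound is needed:

compound 1 `Cc1cccc(-c2n[nH]c(-c3ccccc3)n2)c1`: > 20 mg/kg
compound 2 `COc1cccc(-c2n[nH]c(-c3ccccc3C)n2)c1`: 0.08 mg/kg

Compound 1 gives > 20 mg/kg in this assay, and that value is a limit of the assay rather than a number (the limit of > 20 mg/kg in this assay, at which 1 of the 2 values shown sits). Compound 2 gives 0.08 mg/kg in this assay, and it stands as the only number shown. The two measured compounds differ from each other in more than one place. Going by the values given here, no step between them can be drawn, and their two values show only that compound 2 reaches a number where compound 1 reaches a limit.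

Compound 3 `COc1cccc(-c2n[nH]c(-c3ccccc3C(C)C)n2)c1` has not yet been measured in this assay. It differs from compound 2 by isopropyl in place of methyl on an aromatic carbon. Among the compounds with values here, with no measured step to lean on, the step of a 2.5-fold higher number from compound 2 to compound 3 (0.40 log units; beyond the scatter) is expected to be a modest rise in dose, at the edge of the usual scatter. Compound 3 is therefore expected to give 0.2 mg/kg in this assay, with a range from 0.04 mg/kg to 1 mg/kg.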

Compound 3, dose for half-maximal effect: 4 mg/kg
For compound 3 the middle estimate is 20-fold (1.30 log units) below the measured one, outside the stated range (above it).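

Going by these compounds alone, until now no step could be drawn at this position, on an aromatic carbon ortho to a large group. The change of methyl to isopropyl now provides one in this assay, a 50-fold higher number from compound 2 to compound 3 (1.70 log units; beyond the scatter), so this position is clearly not indifferent to which of these two groups it carries. Only carbon leaves and enters, with no ring, hydrogen-bond donor, hydrogen-bond acceptor or net charge on either side, yet this single change is enough to raise the dose needed by a large margin. Compound 1 differs from compound 3 in more than one place and stays a limit rather than a number, so it adds no further step at this position: the limit of > 20 mg/kg in this assay, at which 1 of the 3 values shown sits.

Within the data shown here, only two groups can be compared at this position, so it remains open whether an ethyl group, a chlorine atom or an amine there would sit close to compound 2, close to compound 3 or elsewhere. The compounds also leave open why the dose needed rises, and whether the same change would have a step of similar size on a different core.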